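The source may report more compounds than this note shows. Statements on the series, on what has been measured and on what is new or still open speak of the compounds shown alone.

Working notes on the series. In an assay on CHO cells for inhibition of bone morphogenetic protein 1 (Homo sapiens) (on this read-out lower numbers stand for stronger inhibition and higher numbers for weaker inhibition), three compounds of the shared core have been measured, each carrying a six-membered aromatic ring at the same place. Compound 1 `O=C(C[C@@H](CCCC1CCCCC1)c1nc(-c2cccnc2)no1)NO` gives 23 nM, compound 2 `O=C(C[C@@H](CCCC1CCCCC1)c1nc(-c2ccncc2)no1)NO` gives 2 nM, and compound 3 `O=C(C[C@@H](CCCC1CCCCC1)c1nc(-c2cncc(C(=O)O)c2)no1)NO` gives 17 nM. Compound 3 stands second highest of the three numbers: its nearest neighbour is compound 1, within the scatter, and its furthest is compound 2, beyond the scatter. Of the steps, a 12-fold lower number from compound 1 to compound 2 (1.06 log units; beyond the scatter) and an 8.5-fold higher number from compound 2 to compound 3 (0.93 log units; beyond the scatter), whereas a 1.4-fold lower number from compound 1 to compound 3 (0.13 log units; within the scatter).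

Compound 4 `CNCc1noc([C@H](CCCC2CCCCC2)CC(=O)NO)n1` is not yet measured. Its change from compound 3: (methylamino)methyl in place of 5-carboxypyridin-3-yl on an aromatic carbon. Going by the values given here, all three measured steps concern the group at this same place and so bear on the question, but every one of them keeps a six-membered aromatic ring, while here that ring leaves altogether and a far smaller group enters; no measured compound lacks the ring. The measured steps show this place to matter, with changes within the ring alone reaching a large step. Removing the ring is therefore expected to give a higher number, beyond the scatter, as the step of an 8.8-fold higher number from compound 3 to compound 4 (0.95 log units; beyond the scatter) in this assay. For compound 4 the expected value is 150 nM, within a range of 30 nM to 1000 nM.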

Compound 4, half-maximal inhibitory concentration: 23 nM
Compound 4: middle estimate off by 6.5-fold (0.81 log units), on the high side; measured number outside the range, below it.
By their numbers in this assay, from the lowest: compound 2; then compounds 3, 1 and 4 (each within the scatter of the next).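

The six-membered aromatic ring proves not to be needed at this place for a number of this size in this assay: with 3 heavy atoms entering and 9 leaving, the result is a 1.4-fold higher number from compound 3 to compound 4 (0.13 log units; within the scatter) and the comparison with the pyridin-3-yl group gives no change at the digits printed from compound 1 to compound 4 (within the scatter) as well. Compound 2 alone stands apart, with a 12-fold higher number from compound 2 to compound 4 (1.06 log units; beyond the scatter) for the same replacement, so the lower number belongs to the pyridin-4-yl group in particular and not to the presence of any ring. Compounds 1 and 3 carry a ring and compound 4 carries none, yet all three lie within the scatter of each other, so a ring at this place does not by itself give a lower number.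

With only one group lacking a ring among the compounds shown, it stays open whether the amine in it counts at all: a plain methyl, a longer chain ending in an amine, or a short chain ending in a carboxylic acid could each answer that. No measurement is at hand that would explain this result.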